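Swapping tert-butoxy for 3-hydroxypiperidin-1-yl in compound 4

A few compounds are considered here, and "the series" means these few. Any claim that something is new, unique, unknown or untested is made for them only; others in the source may bear on it.

Compound 3 `Cc1cc(OC(C)(C)C)c(S(C)(=O)=O)cc1C(=O)N=C(N)N` carries a tert-butoxy group on the shared core. In a functional assay for inhibition of sodium/hydrogen exchanger (Oryctolagus cuniculus) (a lower number here means a stronger inhibitor, a higher number a weaker inhibitor), compound 3 gives 9.4 nM, the lowest number of the three measured compounds. Where compound 3 bears tert-butoxy, compound 1 `Cc1cc(Cl)c(S(C)(=O)=O)cc1C(=O)N=C(N)N` bears a chloro group and gives 25 nM in this assay, and compound 2 `Cc1cc(Sc2ccc(Cl)cc2)c(S(C)(=O)=O)cc1C(=O)N=C(N)N` bears a (4-chlorophenyl)sulfanyl group and gives 19 nM. The step of a 1.3-fold lower number from compound 1 to compound 2 (0.12 log units; within the scatter) is within the scatter, whereas a 2.7-fold lower number from compound 1 to compound 3 (0.42 log units; beyond the scatter) and a 2.0-fold lower number from compound 2 to compound 3 (0.31 log units; beyond the scatter) are both modest but beyond it, so compound 3 stands somewhat apart from the other two.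

Compound 4 `Cc1cc(N2CCCC(O)C2)c(S(C)(=O)=O)cc1C(=O)N=C(N)N` differs from compound 3 by 3-hydroxypiperidin-1-yl in place of tert-butoxy on an aromatic carbon. Within the data shown here, no measured step introduces a nitrogen-linked ring or a hydrogen-bond donor at this carbon, so the three measured steps bear on the change only loosely: they show that replacements at this position have so far shifted the number by modest amounts in either direction or not beyond the scatter. Compound 4 is therefore expected to give about 15 nM in this assay, with a range from 4 nM to 60 nM. For compound 4 this means an expected 1.6-fold higher number from compound 3 to compound 4 (0.20 log units; within the scatter), a step that may well stay within the scatter.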

Compound 4, half-maximal inhibitory concentration: 30 nM
Estimate against measurement, compound 4: 2.0-fold (0.30 log units) below; low and high end bracket the measured number.
By their numbers in this assay, from the lowest: compound 3; then compounds 2, 1 and 4 (each within the scatter of the next).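

In this assay the step of a 3.2-fold higher number from compound 3 to compound 4 (0.50 log units; beyond the scatter) is modest but beyond the scatter, so at this aromatic carbon, ortho to the methylsulfonyl group, tert-butoxy and 3-hydroxypiperidin-1-yl can be told apart. The same ring cannot be told apart from the two other groups: both a 1.6-fold higher number from compound 2 to compound 4 (0.20 log units; within the scatter) and a 1.2-fold higher number from compound 1 to compound 4 (0.08 log units; within the scatter) lie within the scatter, so a nitrogen-linked ring bearing a hydrogen-bond donor sits level with chloro and (4-chlorophenyl)sulfanyl, and compound 3 alone now stands apart from all the others with its tert-butoxy group. No measurement given here accounts for the difference between the tert-butoxy and 3-hydroxypiperidin-1-yl groups.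

The compounds shown leave open whether the higher number of compound 4 relative to compound 3 goes with the ring, its nitrogen link or its hydroxy group. An unsubstituted piperidin-1-yl group, a morpholin-4-yl group or a 3-aminopiperidin-1-yl group at the same carbon would begin to separate these parts of the change.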